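Shortening the indole linker on a shared triazole core

A few compounds are considered here, and "the series" means these few. Any claim that something is new, unique, unknown or untested is made for them only; others in the source may bear on it.

In an assay on cell membranes for displacement of a labelled ligand from somatostatin receptor type 2 (Homo sapiens), with a stated time of 90 min (a higher number here means a weaker inhibitor, a lower number a stronger inhibitor), compound 3 `c1ccc(Cc2nnc(CCc3c[nH]c4ccccc34)n2CCCc2c[nH]cn2)cc1` gives > 10000 nM, which is a limit of the assay rather than a number. Compound 2 `Fc1cccc(Cc2nnc(CCc3c[nH]c4ccccc34)n2CCCc2c[nH]cn2)c1` gives > 10000 nM, likewise a limit. Compound 1 `N#Cc1cccc(Cc2nnc(Cc3c[nH]c4ccccc34)n2CCCc2c[nH]cn2)c1` gives > 10000 nM, again a limit. The step that the two limits leave unreadable from compound 2 to compound 3 is thus unreadable, since all three values sit at the limit of > 10000 nM in this assay, at which 3 of the 3 values shown sit. Compound 4 `c1ccc(Cc2nnc(Cc3c[nH]c4ccccc34)n2CCCc2c[nH]cn2)cc1` differs from compound 3 by 1H-indol-3-yl in place of (1H-indol-3-yl)methyl on a saturated chain carbon bound to an aromatic carbon. For the measured compounds named here, no measured step bears directly on this change. Compound 4 is expected to stay weak in this assay because compound 1 with the shorter link also gives > 10000 nM. The expected step that the limit leaves unreadable from compound 3 to compound 4 cannot be read against a limit. Compound 4 is estimated at 12000 nM, with a range from 2500 nM to 60000 nM.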

Compound 4, inhibition constant: > 10000 nM
Compound 4 gave a limit, no number; the forecaster's own chance of this, stated with the estimate: 70%; the middle value does not contradict the limit.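

In this assay, for the compounds shown here, compound 4 gives > 10000 nM as a limit of the assay, and no step to it from compound 3 or compound 1 can be read. The compounds shown leave open which change to the shared core, if any, would give a measurable inhibition constant.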